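The source may hold more compounds than are shown below. What is called first, only, known or untested is meant among the compounds shown, and "the series" means these compounds.

Compound 1 `COc1ccc(C(=O)NCCNc2nc3cc(C)cc(C)c3cc2C#N)cc1` gives, in an in vitro assay on FRT cells with Cystic fibrosis transmembrane conductance regulator variant F508del (Homo sapiens) as the target, read by fluorescence, with a stated time of 24 h, at 37 degrees C, in the presence of a further agent that is not named here (on this read-out higher numbers stand for an effect only at larger amounts of compound and lower numbers for an effect already at smaller amounts), a value of 3000 nM, the lowest of the two numbers in hand; compound 2 `Cc1cc(C)c2cc(C#N)c(NCCNC(=O)c3ccncc3)nc2c1` gives 7300 nM, and the step of a 2.4-fold higher number from compound 1 to compound 2 (0.39 log units; beyond the scatter) comes from swapping one aryl group on the carbonyl for another. Compound 3 `COc1ccc(C(=O)NCCNc2nc3cc(C)cc(C)c3cc2C#N)c(OC)c1` differs from compound 1 by methoxy in place of hydrogen on an aromatic carbon. For the measured compounds named here, no measured step bears on this change; the only known step concerns a different part of the molecule. A step of a 1.2-fold lower number from compound 1 to compound 3 (0.08 log units; within the scatter) is therefore expected, within the scatter, and for compound 3 the estimated value in this assay is 2500 nM, between 1000 nM and 7000 nM.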

Compound 3, half-maximal effective concentration: 4200 nM
Compound 3: the middle estimate sits 1.7-fold (0.23 log units) below what was measured; the measured number falls inside the stated range.
By their numbers in this assay, from the lowest: compounds 1, 3 and 2 (each within the scatter of the next, the first and the last beyond it).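

Methoxy in place of hydrogen on an aromatic carbon, ortho to a large group, turns 4-methoxyphenyl into 2,4-dimethoxyphenyl, and in this assay this gives a 1.4-fold higher number from compound 1 to compound 3 (0.15 log units; within the scatter), so the added group leaves the read-out unresolved from that of the parent. Measured against the pyridin-4-yl amide, the same ring gives a 1.7-fold lower number from compound 2 to compound 3 (0.24 log units; within the scatter), so compound 3 cannot be separated from either neighbour, although those two differ beyond the scatter. Nothing available accounts for this result. Going by these compounds, what an amine or a carboxylic acid would do at this position remains open, as does a longer chain in place of the methoxy.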